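Working notes: bromo to tert-butyl on the shared core

A few compounds are considered here, and "the series" means these few. Any claim that something is new, unique, unknown or untested is made for them only; others in the source may bear on it.

compound 1 `Cc1ccc(SCc2ccc(C(=O)Nc3ccccc3N)cc2)cc1`: 40.5%
compound 2 `Nc1ccccc1NC(=O)c1ccc(CSc2ccc(Br)cc2)cc1`: 33.2%

Going by the values given here, in a functional assay on A549 cells (Homo sapiens) for inhibition, read by CCK-8 assay, with a stated time of 72 h, tested at 2 uM (on this read-out higher numbers stand for more inhibition of growth at the one concentration tested and lower numbers for less inhibition of growth), compound 2 gives 33.2% and has compound 1 as its only neighbour on the numbers. Compound 3 `CC(C)(C)c1ccc(SCc2ccc(C(=O)Nc3ccccc3N)cc2)cc1` follows from compound 2 by tert-butyl in place of bromo on an aromatic carbon as tert-butyl in place of bromo on an aromatic carbon, para to a large group. Among the compounds with values here, only one measured step bears on this place: a number 7.3 percentage points lower from compound 1 to compound 2 (within the scatter) for bromo in place of methyl. Within the data shown here, no step beyond the scatter is therefore expected in this assay for this change, although no measured compound carries tert-butyl. The estimated step is a number 3.8 percentage points higher from compound 2 to compound 3 (within the scatter) as a working expectation. Compound 3 is expected at 37% with an estimated range from 20% to 55% on this read-out.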

Compound 3, percent growth inhibition at one concentration: 38.6%
Estimate against measurement, compound 3: 1.6 percentage points below; the range from low to high includes it.
By their numbers in this assay, from the lowest: compounds 2, 3 and 1 (each within the scatter of the next).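

Tert-butyl, with 4 heavy atoms against the 1 of bromo, gives a third substituent at this place on the shared core, and this assay still separates none of them: the readings are a number 5.4 percentage points higher from compound 2 to compound 3 (within the scatter) and a number 1.9 percentage points lower from compound 1 to compound 3 (within the scatter), so a larger group here brings no step beyond the scatter. No supporting measurement bears on this result.

On these data alone, whether an amine or a carboxylic acid at this place would give a step beyond the scatter stays open. So does the behaviour of these compounds at any other concentration.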